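A few compounds are considered here, and "the series" means these few. Any claim that something is new, unique, unknown or untested is made for them only; others in the source may bear on it.

Measured in a physicochemical assay for solubility, at pH 7; a higher number here means a more soluble compound, a lower number a less soluble compound:
- Compound 1 `CN1CCC(C(=O)N2Cc3c(NC(=O)C4CCC4)n[nH]c3C2(C)C)CC1`: > 225000 nM, a limit
- Compound 2 `CN1CCC(C(=O)N2Cc3c(NC(=O)c4cc(F)cc(F)c4)n[nH]c3C2(C)C)CC1`: > 225000 nM, a limit

Compound 2 gives > 225000 nM, which is a limit of the assay and not a number. The record so far amounts to the limit of > 225000 nM in this assay, at which 2 of the 2 values shown sit.

Compound 3 `CN1CCC(C(=O)N2Cc3c(NC(=O)c4ccc(Cl)cc4)n[nH]c3C2(C)C)CC1` brings the next change: 4-chlorophenyl in place of 3,5-difluorophenyl on a carbonyl carbon. In words, 4-chlorophenyl stands in place of 3,5-difluorophenyl on a carbonyl carbon. Among the compounds with values here, one measured step bears on this, made on the same carbonyl carbon: a step that the two limits leave unreadable from compound 1 to compound 2. Within the data shown here, its size cannot be read, and it shows only that both compounds end at a limit. Among the measured compounds shown here, with that step as the only guide, no change beyond the scatter is expected in this assay, though a readable value could only fall lower. The expected step is an at least 1.1-fold lower number from compound 2 to compound 3 (0.05 log units; that floor lies within the scatter). For compound 3 the estimate is 200000 nM, with an expected range of 90000 nM to 225000 nM.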

Compound 3, solubility: > 225000 nM
Compound 3: no number, only a limit (the forecaster's own chance of this, stated with the estimate: 60%); at least 1.1-fold (0.05 log units) between middle value and limit.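

In this assay, within the data shown here, compound 3 gives > 225000 nM, which is a limit and not a number, so no step among compound 1, compound 2 and compound 3 can be read. The compounds shown leave open how these three compare in this assay, and whether any group on the carbonyl carbon would give a readable value.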